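Putting dimethylamino in place of 1H-imidazol-1-yl

The compounds below may be only part of what the source reports. "The series", "measured", "known", "first", "only" and "open" are said of these compounds alone.

In a functional assay on the whole organism for antagonist activity, with Mus musculus as the target (a higher number here means that more compound is needed for the effect, a lower number that less compound is needed), compound 1 (`CC(C#CCn1ccnc1)N1CCCC1=O`) gives 45 mg/kg and compound 2 (`Cc1cncn1CC#CC(C)N1CCCC1=O`) gives 25.4 mg/kg, two values within the scatter of each other. Compound 3 (`CC(C#CCN(C)C)N1CCCC1=O`) carries dimethylamino in place of 1H-imidazol-1-yl on a saturated chain carbon bound to a triple-bonded carbon. Within the data shown here, the only measured step, a 1.8-fold lower number from compound 1 to compound 2 (0.25 log units; within the scatter), comes from methyl in place of hydrogen on an aromatic carbon and keeps the ring, so it sets no direction for this change. The expected step is a 1.5-fold lower number from compound 1 to compound 3 (0.18 log units; within the scatter), with none estimated beyond the scatter. Compound 3 is estimated at 30 mg/kg, with an expected range of 8 mg/kg to 110 mg/kg.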

Compound 3, dose for half-maximal effect: > 100 mg/kg
Compound 3 ended at the assay's limit; the forecaster's own chance of this, stated with the estimate: 25%; at least 3.3-fold (0.52 log units) between middle value and limit.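

In this assay, dimethylamino in place of 1H-imidazol-1-yl on a saturated chain carbon bound to a triple-bonded carbon gives an at least 2.2-fold higher number from compound 1 to compound 3 (0.34 log units; beyond the scatter). Unlike the earlier methyl change, which stayed within the scatter, this shows that the number responds to what sits at this position. The value of compound 3 is a limit of the assay, not a number: the limit of > 100 mg/kg in this assay, at which 1 of the 3 values shown sits.

As far as these compounds go, how far compound 3 lies past that limit stays open. So does whether another amine, such as diethylamino, would behave like dimethylamino or like 1H-imidazol-1-yl.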